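Arylidene-indolinone series: aldehyde for fluorine on the benzylidene

A few compounds are considered here, and "the series" means these few. Any claim that something is new, unique, unknown or untested is made for them only; others in the source may bear on it.

Of the compounds shown here, two have numbers so far. Compound 1 `CN(C)CCn1c(=O)c(=Cc2ccc(F)cc2F)s/c1=C1\C(=O)Nc2cc(F)ccc21` gives 6460 nM in a functional assay on HT-29 cells (Homo sapiens) for inhibition, read by MTT assay, with a stated time of 72 h; a higher number here means a weaker inhibitor, a lower number a stronger inhibitor. Compound 2 `CCN(CC)CCCn1c(=O)c(=Cc2ccc(O)cc2)s/c1=C1\C(=O)Nc2ccc(C)cc21` gives 770 nM in this assay. Compound 1 therefore stands with the highest number of the two; the gap between compound 1 and compound 2 lies beyond the usual scatter of the measurement, but the two structures differ in more than one place, so the gap cannot be attributed to any single change and only the two values themselves can be stated.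

The next compound to be measured is compound 3 `CN(C)CCn1c(=O)c(=Cc2ccc(C=O)c(C=O)c2)s/c1=C1\C(=O)Nc2cc(F)ccc21`. It differs from compound 1 in one place only: 3,4-diformylphenyl in place of 2,4-difluorophenyl on a double-bonded chain carbon bound to an aromatic carbon. Among the measured compounds shown here, no pair of measured compounds that differ in one place is available, so the size of this step can only be estimated. The expectation is a small step, if any, toward a lower number, of a size that would remain within the usual scatter. For compound 3 the estimate in this assay is 4000 nM, with a range from 1000 nM to 16000 nM, which corresponds to an expected step of a 1.6-fold lower number from compound 1 to compound 3 (0.21 log units; within the scatter).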

Compound 3, half-maximal inhibitory concentration: 1360 nM
Compound 3: the middle estimate sits 2.9-fold (0.47 log units) above what was measured; low and high end bracket the measured number.
By their numbers in this assay, from the lowest: compounds 2 and 3 (each within the scatter of the next); then compound 1.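

Among the compounds shown here, this is the first step that can be read at one place: in this assay, a 4.8-fold lower number from compound 1 to compound 3 (0.68 log units; beyond the scatter) when 3,4-diformylphenyl replaces 2,4-difluorophenyl on a double-bonded chain carbon bound to an aromatic carbon. The group at this place therefore matters to the read-out, at least for this pair, with the rest of compound 1 held constant. The change alters several counted features at once, since both fluorines leave while two hydrogen-bond acceptors and two double bonds outside aromatic rings enter, and the available data offer no explanation for the step.

Going by these compounds, it remains open which part of the change goes with the lower number, and a phenyl with a single formyl, or one carrying a nitrile or a carboxylic acid in place of the formyl groups, would help to separate these features. It also remains open whether a step of this size would hold on a different side chain or with a different substituent on the shared core, as neither comparison can be read from the compounds shown.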